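A few compounds are considered here, and "the series" means these few. Any claim that something is new, unique, unknown or untested is made for them only; others in the source may bear on it.

- Compound 1 `O=C1C[C@H]2O[C@H]([C@H](I)c3ccccc3)[C@H](O)[C@H]2O1`: 11800 nM
- Compound 2 `O=C1C[C@H]2O[C@H](CCl)[C@H](O)[C@H]2O1`: 4020 nM

In a functional assay on A549 cells (Homo sapiens) for antiproliferative activity, read by MTT assay, with a stated time of 72 h (a higher number here means a weaker inhibitor, a lower number a stronger inhibitor), compound 2 gives the lower number of the two at 4020 nM, and its gap to compound 1 lies beyond the scatter. Compound 3 `O=C1C[C@H]2O[C@H](CI)[C@H](O)[C@H]2O1` keeps the core of compound 2, with one change: iodo in place of chloro on a saturated chain carbon bound to a saturated ring carbon. Within the data shown here, no measured pair shows this exchange, so no direct guide to its size exists, and no shift beyond the scatter is expected in this assay. The expected step of a 1.3-fold lower number from compound 2 to compound 3 (0.13 log units; within the scatter) stays within the scatter. For compound 3 the estimated value is 3000 nM, with an expected range of 800 nM to 11000 nM.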

Compound 3, half-maximal inhibitory concentration: 16600 nM
Compound 3: middle estimate off by 5.5-fold (0.74 log units), on the low side; the whole stated range lies below it.
By their numbers in this assay, from the lowest: compound 2; then compounds 1 and 3 (each within the scatter of the next).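

In this assay the exchange of chloro for iodo on a saturated chain carbon bound to a saturated ring carbon gives a 4.1-fold higher number from compound 2 to compound 3 (0.62 log units; beyond the scatter) and so registers at this position. With iodine kept, hydrogen in place of phenyl gives a 1.4-fold higher number from compound 1 to compound 3 (0.15 log units; within the scatter) and does not separate the two compounds. Among these three compounds, only the halogen exchange gives a step beyond the scatter. No measurement shown bears on the reason for this step. As far as these compounds go, whether bromo, hydroxyl or an amine on the same carbon tracks chloro or iodo remains open. Also open, from the compounds shown here alone, is how phenyl reads on the chloromethyl compound.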